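Sulfonamide Replaces Ester Before the Cytotoxicity Read-out

The source may hold more compounds than are shown below. What is called first, only, known or untested is meant among the compounds shown, and "the series" means these compounds.

Of the compounds shown here, three sharing one core have been tested in an ADME assay on MT4 cells (Homo sapiens) for cytotoxicity, read by MTT assay, with a stated time of 4 days; on this read-out lower numbers stand for higher toxicity in this test and higher numbers for lower toxicity in this test. Compound 1 `CCOC(=O)c1cnc(N2CCN(Cc3cccc(C#N)c3)CC2)nc1Oc1c(C)cc(-c2ccc(C#N)cc2)cc1C` carries a 3-cyanophenyl group on a saturated chain carbon bound to an amine nitrogen in a ring. In this assay compound 1 reaches only a limit of the assay, > 125000 nM. Compound 2 `CCOC(=O)c1cnc(N2CCN(Cc3ccc(C(=O)OC)cc3)CC2)nc1Oc1c(C)cc(-c2ccc(C#N)cc2)cc1C` carries 4-(methoxycarbonyl)phenyl at that place, and in this assay compound 2 likewise sits at a limit, > 125000 nM. Compound 3 `CCOC(=O)c1cnc(N2CCN(Cc3ccccc3C(=O)OC)CC2)nc1Oc1c(C)cc(-c2ccc(C#N)cc2)cc1C` bears 2-(methoxycarbonyl)phenyl, and in this assay compound 3 stops at a limit, > 125000 nM. Because all three values share (the limit of > 125000 nM in this assay, at which 3 of the 3 values shown sit), the steps among them cannot be read: a step that the two limits leave unreadable from compound 1 to compound 2, a step that the two limits leave unreadable from compound 1 to compound 3 and a step that the two limits leave unreadable from compound 2 to compound 3. Compound 3 therefore stands where the other two stand, at a limit and not at a number.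

Compound 4 `CCOC(=O)c1cnc(N2CCN(Cc3ccc(S(N)(=O)=O)cc3)CC2)nc1Oc1c(C)cc(-c2ccc(C#N)cc2)cc1C` is not yet measured. It differs from compound 3 in one place: 4-sulfamoylphenyl in place of 2-(methoxycarbonyl)phenyl on a saturated chain carbon bound to an amine nitrogen in a ring. Going by the values given here, no measured step concerns a sulfamoyl group, and the three steps that do exist give no size at all. Since compounds 1, 2 and 3 all sit at the limit of > 125000 nM in this assay, at which 3 of the 3 values shown sit, the expectation for compound 4 is no step beyond the scatter, with a number no higher from compound 3 to compound 4 (the limit leaves the size open) as the expected step. Compound 4 is thus estimated in this assay at 125000 nM, within a range from 60000 nM to 300000 nM, most likely again only a limit.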

Compound 4, half-maximal cytotoxic concentration: >= 7930 nM
Compound 4: only a limit was reported; the forecaster's own chance of this, stated with the estimate: 85%; the middle value lies beyond the limit too.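

In this assay compound 4 gives >= 7930 nM, which is a limit and not a number. Compounds 1, 2 and 3 also stand only at limits, so none of the steps from them to compound 4 can be read. The compounds shown leave open whether 4-sulfamoylphenyl differs at all from the groups it was compared with on this read-out.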